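The source may hold more compounds than are shown below. What is called first, only, known or untested is meant among the compounds shown, and "the series" means these compounds.

Measured compounds:
compound 1 `Cc1n[nH]c2c1[C@@H](c1ccc(OCc3ccccc3F)cc1)S[C@@H](C)C(=O)N2`, > 200000 nM in an ADME assay on L929 cells (Mus musculus) for cytotoxicity, read by microscopy, with a stated time of 96 h; on this read-out higher numbers stand for lower toxicity in this test and lower numbers for higher toxicity in this test
compound 2 `COc1cc([C@H]2S[C@@H](C)C(=O)Nc3[nH]nc(C)c32)ccc1OCc1ccccc1`, "not determined" (no result reported) in this assay

Compound 1 gives only a limit of this assay, > 200000 nM, so its lethal concentration is not known as a number. Within the data shown here, compound 2 stands without a result of its own in this assay; the one value that exists in this set is the limit (the limit of > 200000 nM in this assay, at which 1 of the 2 values shown sits). Compound 3 `COc1cc([C@H]2S[C@@H](C)C(=O)Nc3[nH]nc(C)c32)ccc1OCc1ccc(Cl)cc1` differs from compound 2 by chloro in place of hydrogen on an aromatic carbon. Among the measured compounds shown here, no measured step is available here; with chloro in place of hydrogen the step in this assay is expected to stay within the scatter. Compound 3 is therefore estimated at 200000 nM, within 50000 nM to 600000 nM.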

Compound 3, concentration lethal to 50% of the cells: 50600 nM
Beside the measured number, compound 3's estimate is 4.0-fold (0.60 log units) above it; the range from low to high includes it.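

No step can be read between compound 2 and compound 3 in this assay. On these data alone, what chloro in place of hydrogen, benzyloxy to (4-chlorobenzyl)oxy, does to the lethal concentration on the shared core remains open.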